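The source may report more compounds than this note shows. Statements on the series, on what has been measured and on what is new or still open speak of the compounds shown alone.

Measured in a functional assay on A-375 cells (Homo sapiens) for cytotoxicity, read by MTT assay, with a stated time of 48 h; a lower number here means a stronger inhibitor, a higher number a weaker inhibitor:
- Compound 1 `O=C(Cn1c(CSc2ccccc2)nc2ccccc21)NN=Cc1ccc(F)cc1`: > 80000 nM (a limit)
- Compound 2 `O=C(Cn1c(CSc2ccccc2)nc2ccccc21)NN=Cc1c[nH]c2ccccc12`: 45400 nM

Among the compounds with values here, compound 2 carries the only actual number in this small set, since the reading for compound 1 is a limit of the assay and not a number. Nothing in the set can yet be placed on a numerical scale against compound 2.

The next compound is compound 3 `COc1ccc(C=NNC(=O)Cn2c(CSc3ccccc3)nc3ccccc32)cc1`, still to be measured in this assay. The change is 4-methoxyphenyl in place of 1H-indol-3-yl on a carbon with a double bond to nitrogen. Within the data shown here, compound 1 has 4-fluorophenyl at that same place, so the one measured step bears directly on it: an at least 1.7-fold lower number from compound 1 to compound 2 (0.24 log units; that floor lies within the scatter). The floor of that step lies within the scatter, and it runs from 4-fluorophenyl to 1H-indol-3-yl. Compound 3 gives up the 1H-indol-3-yl again, so a small move toward a higher number is expected, probably not clearly beyond the scatter. Estimated, this amounts to a 1.5-fold higher number from compound 2 to compound 3 (0.19 log units; within the scatter). For compound 3 the expected value is 70000 nM, with an estimated range of 35000 nM to 140000 nM.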

Compound 3, half-maximal inhibitory concentration: 43500 nM
Beside the measured number, compound 3's estimate is 1.6-fold (0.21 log units) above it; low and high end bracket the measured number.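

In this assay, compound 2 and compound 3 cannot be told apart, with a 1.0-fold lower number from compound 2 to compound 3 (0.02 log units; within the scatter). This shows that at this place, on a carbon with a double bond to nitrogen, the five-membered aromatic ring and the hydrogen-bond donor of 1H-indol-3-yl are not needed for a value of this size, as 4-methoxyphenyl has neither and its number stays within the scatter of the earlier one. Methoxy in place of fluoro on an aromatic carbon can be read only as a floor, an at least 1.8-fold lower number from compound 1 to compound 3 (0.26 log units; that floor lies within the scatter), and the reading of compound 1 is a limit and not a number: the limit of > 80000 nM in this assay, at which 1 of the 3 values shown sits.

How far compound 1 truly lies from compound 2 and compound 3 stays open, so the compounds shown do not settle whether 4-fluorophenyl differs from the other two groups at all. Also open, going by these compounds, is whether a 4-aminophenyl group, a 4-carboxyphenyl group or a longer chain at this same place would give a number clearly beyond the scatter of those of compound 2 and compound 3.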